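Fluoro in Place of Chloro on a Serotonin Receptor Ligand

A few compounds are considered here, and "the series" means these few. Any claim that something is new, unique, unknown or untested is made for them only; others in the source may bear on it.

Compound 3 `Clc1ccccc1-c1n[nH]cc1N1CCNCC1` stands at the edge of the numbers shown. In an assay on isolated protein for binding affinity to 5-hydroxytryptamine receptor 6 (Homo sapiens) (a lower number here means a stronger inhibitor, a higher number a weaker inhibitor), compound 3 gives > 10000 nM, which is a limit of the assay and not a number. Compound 1 `COc1ccccc1-c1n[nH]cc1N1CCNCC1` gives > 10000 nM in this assay, also a limit. Among the measured compounds shown here, compound 2 `c1ccc(-c2n[nH]cc2N2CCNCC2)cc1` is the only one with a readable value, giving 185 nM in this assay. Putting chloro in place of hydrogen brought an at least 54-fold higher number from compound 2 to compound 3 (1.73 log units; beyond the scatter), and putting hydrogen in place of methoxy brought an at least 54-fold lower number from compound 1 to compound 2 (1.73 log units; beyond the scatter), so both substituents carried the value to the limit of > 10000 nM in this assay, at which 2 of the 3 values shown sit. Between the two limits the step that the two limits leave unreadable from compound 1 to compound 3.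

Compound 4 `Fc1ccccc1-c1n[nH]cc1N1CCNCC1` differs from compound 3 by fluoro in place of chloro on an aromatic carbon. For the measured compounds named here, no measured step involves fluoro. Going by the values given here, the steps that bear on it are an at least 54-fold higher number from compound 2 to compound 3 (1.73 log units; beyond the scatter) and an at least 54-fold lower number from compound 1 to compound 2 (1.73 log units; beyond the scatter), both large and both leading away from the readable value of compound 2 whenever a substituent occupies that position. Compound 4 is therefore expected to stay weak in this assay, with a fair chance of again reaching only the limit, and its step from the limit of compound 3 is expected to be an at least 2.0-fold lower number from compound 3 to compound 4 (0.30 log units; that floor lies within the scatter). The estimate for compound 4 is 5000 nM, within a range from 800 nM to 20000 nM.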

Compound 4, inhibition constant: 713 nM
Beside the measured number, compound 4's estimate is 7.0-fold (0.85 log units) above it; the measured number lies below the stated range.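

At this position, on an aromatic carbon ortho to a large group, a substituent does not have to carry the value to the limit of this assay: fluoro in place of chloro gave an at least 14-fold lower number from compound 3 to compound 4 (1.14 log units; beyond the scatter), and fluoro in place of methoxy gave an at least 14-fold lower number from compound 1 to compound 4 (1.14 log units; beyond the scatter). The earlier compounds had shown only two substituents there, and neither gave a readable value, whereas fluoro keeps a readable value at a modest cost against hydrogen, with a 3.9-fold higher number from compound 2 to compound 4 (0.59 log units; beyond the scatter), so compound 2 remains the strongest of the four. Compound 4 thus stands apart from compound 1 and compound 3, which share one limit of the assay and not a number: the limit of > 10000 nM in this assay, at which 2 of the 4 values shown sit.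

On these data alone, the step between compound 1 and compound 3 still cannot be read, so the order of chloro and methoxy at this position stays unknown, and the four compounds do not say what separates fluoro from those two groups. As far as these compounds go, whether a methyl, a hydroxyl or an amine at this position would keep a readable value like fluoro or reach the limit like chloro and methoxy remains open.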